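The compounds below may be only part of what the source reports. "The series", "measured", "known", "first", "only" and "open" are said of these compounds alone.

In a functional assay on MCF7 cells (Homo sapiens) for antiproliferative activity, read by CCK-8 assay, with a stated time of 24 h (on this read-out higher numbers stand for weaker inhibition and lower numbers for stronger inhibition), the measured compounds so far are:
- compound 1 `CN(C)Cc1ccc2nc(NC(=O)N/N=C/c3ccccn3)sc2c1` gives > 40000 nM
- compound 2 `C/C(=N\NC(=O)Nc1nc2ccc(CN(C)C)cc2s1)c1ccccn1` gives > 40000 nM
- compound 3 `CN(C)Cc1ccc2nc(NC(=O)NN=C(c3ccccn3)c3ccccn3)sc2c1` gives > 40000 nM

The series stands at the limit of > 40000 nM in this assay, at which 3 of the 3 values shown sit, so none of the three has a number. Compound 2 is a limit of the assay, with no value to rank it by. Compound 4 `C/C(=N\NC(=O)Nc1nc2ccc(CN(C)C)cc2s1)c1cnccn1` carries pyrazin-2-yl in place of pyridin-2-yl on a carbon with a double bond to nitrogen. Among the compounds with values here, no measured step covers this change. Resting on compound 2 and its limit of > 40000 nM, the expected result in this assay is a number no higher from compound 2 to compound 4 (the limit leaves the size open), with no change beyond the scatter in either direction. Compound 4 is estimated at 40000 nM, with an expected range from 20000 nM to 80000 nM, and will most likely be reported as a limit again.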

Compound 4, half-maximal inhibitory concentration: > 40000 nM
Compound 4 gave a limit, no number; the forecaster's own chance of this, stated with the estimate: 85%; the middle value sits exactly at the limit.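

In this assay compound 4 gives > 40000 nM, a limit and not a number. Within the data shown here, compound 2 is also a limit, so no step from compound 2 to compound 4 can be read. The compounds shown leave open whether pyrazin-2-yl in place of pyridin-2-yl alters activity, and how any of them ranks: the limit of > 40000 nM in this assay, at which 4 of the 4 values shown sit.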